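Working notes: from compound 2 to compound 3

A few compounds are considered here, and "the series" means these few. Any claim that something is new, unique, unknown or untested is made for them only; others in the source may bear on it.

- compound 1 `CC(C)(C)n1cc(C(=O)O)c(=O)c2cc(F)c(N3CC4CC3CN4)nc21` gives 80 ug/mL
- compound 2 `Cc1c(F)c(N2CC3CC2CN3)nc2c1c(=O)c(C(=O)O)cn2C1CC1` gives 20 ug/mL

In a physicochemical assay for solubility (on this read-out higher numbers stand for higher solubility and lower numbers for lower solubility), compound 2 stands lowest of the two measured compounds at 20 ug/mL, with compound 1 higher beyond the scatter. Compound 3 `O=C(O)c1cn(C2CC2)c2nc(N3CC4CC3CN4)c(F)cc2c1=O` carries hydrogen in place of methyl on an aromatic carbon, opposite the ring nitrogen (hydrogen in place of methyl on an aromatic carbon). For the measured compounds named here, no measured step isolates this change, so only a small upward move in this assay is expected, possibly none beyond the scatter. The estimated move is a 1.8-fold higher number from compound 2 to compound 3 (0.24 log units; within the scatter). Compound 3 is expected at 35 ug/mL, within an estimated range of 12 ug/mL to 100 ug/mL.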

Compound 3, solubility: 90 ug/mL
The estimate for compound 3 lay 2.6-fold (0.41 log units) below the measured number; low and high end bracket the measured number.
By their numbers in this assay, from the lowest: compound 2; then compounds 1 and 3 (each within the scatter of the next).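

In this assay, for the compounds shown here, the aromatic carbon opposite the ring nitrogen proves sensitive: hydrogen in place of methyl there gives a 4.5-fold higher number from compound 2 to compound 3 (0.65 log units; beyond the scatter) as the first measured step at this position. Cyclopropyl in place of tert-butyl on the aromatic nitrogen gives a 1.1-fold higher number from compound 1 to compound 3 (0.05 log units; within the scatter) and so separates the two compounds by no more than the scatter. No measurement on hand bears on the reason for either step.

From the compounds shown here alone, whether the methyl step holds with tert-butyl on the aromatic nitrogen remains open. So does the outcome with chloro, methoxy or an amine on this carbon.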